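This account rests on a few compounds, and the source may have more. Where it says the series, first, only, none or still open, it means among the compounds named here.

In an assay on CHO cells for displacement of a labelled ligand from adenosine receptor A1 (Homo sapiens) (on this read-out lower numbers stand for stronger inhibition and higher numbers for weaker inhibition), three compounds sharing one core have been measured. Compound 1 `COc1ccc(-c2c(C#N)c(N)nc(SCc3csc(-c4ccc(Cl)c(Cl)c4)n3)c2C#N)cc1` gives 11 nM, compound 2 `COc1ccc(-c2c(C#N)c(N)nc(SCc3nc(-c4ccc(Cl)cc4)sc3Cl)c2C#N)cc1` gives 88 nM, and compound 3 `COc1ccc(-c2c(C#N)c(N)nc(SCc3csc(-c4ccc(Br)cn4)n3)c2C#N)cc1` gives 53 nM. Compound 3 therefore holds the second highest of the three numbers: its nearest neighbour is compound 2, whose value lies within the usual scatter of its own, while its furthest is compound 1, whose value is clearly lower.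

Among the measured compounds shown here, the one measured step that bears on the next compound is the change that leads to compound 3 itself, a 4.8-fold higher number from compound 1 to compound 3 (0.68 log units; beyond the scatter), where a 5-bromopyridin-2-yl group replaced a 3,4-dichlorophenyl group.

Compound 4 `COc1ccc(-c2c(C#N)c(N)nc(SCc3csc(-c4ccc(F)cc4)n3)c2C#N)cc1` now carries 4-fluorophenyl in place of 5-bromopyridin-2-yl on an aromatic carbon. For the measured compounds named here, this change returns a six-membered ring of carbon only to the place that compound 1 occupied with 3,4-dichlorophenyl, but with a single fluorine rather than two chlorines; no measured pair isolates that halogen difference. Given that the swap to the pyridinyl ring raised the number in compound 3, the reverse direction is expected: compound 4 is estimated at 25 nM, within a range of 8 nM to 80 nM, which corresponds to an expected step of a 2.1-fold lower number from compound 3 to compound 4 (0.33 log units; beyond the scatter) in this assay.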

Compound 4, inhibition constant: 2.3 nM
The estimate for compound 4 lay 11-fold (1.04 log units) above the measured number; measured number outside the range, below it.
By their numbers in this assay, from the lowest: compound 4; then compound 1; then compounds 3 and 2 (each within the scatter of the next).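

In this assay, among the compounds shown here, the aromatic carbon of the five-membered ring, next to the ring nitrogen and next to the ring sulfur, proves far more responsive than the single earlier step could show: 4-fluorophenyl in place of 5-bromopyridin-2-yl gives a 23-fold lower number from compound 3 to compound 4 (1.36 log units; beyond the scatter), a large step in which one group of the same heavy-atom count replaces another. Rings of carbon only are also not interchangeable here, since 4-fluorophenyl in place of 3,4-dichlorophenyl gives a 4.8-fold lower number from compound 1 to compound 4 (0.68 log units; beyond the scatter), so the return to an all-carbon ring does not simply restore the earlier level, and the single fluorine goes with a lower number than the two chlorines. Nothing available explains the size or the direction of either step.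

The step between the 5-bromopyridin-2-yl and 4-fluorophenyl groups changes the ring nitrogen and the halogen together, so the compounds shown cannot divide it between the two, and a phenyl ring carrying bromine or a pyridinyl ring carrying fluorine would be needed to separate them. Going by these compounds, how a plain phenyl ring, or a phenyl ring carrying a methoxy group or an amine, would stand at this position also remains open.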